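Working notes: compound 3 to compound 4, nitro to ester

This account rests on a few compounds, and the source may have more. Where it says the series, first, only, none or still open, it means among the compounds named here.

Of the compounds shown here, three have numbers so far in a functional assay on QG-56 cells (Homo sapiens) for antiproliferative activity; a lower number here means a stronger inhibitor, a higher number a weaker inhibitor. Compound 1 `COc1cccc(-c2cc(CN(C)C)cc3cc(C(O)(c4ccc(C#N)cc4)c4cncn4C)oc23)c1` gives 142 nM. Compound 2 `COc1cccc(-c2cc(CO)cc3cc(C(O)(c4ccc(C#N)cc4)c4cncn4C)oc23)c1` gives 16.8 nM, and compound 3 `COc1cccc(-c2cc([N+](=O)[O-])cc3cc(C(O)(c4ccc(C#N)cc4)c4cncn4C)oc23)c1` gives 38.8 nM. Among these three, compound 3 holds the second highest number: its nearest neighbour is compound 2, with a 2.3-fold higher number from compound 2 to compound 3 (0.36 log units; beyond the scatter), and the furthest is compound 1, with a 3.7-fold lower number from compound 1 to compound 3 (0.56 log units; beyond the scatter). The remaining step, an 8.5-fold lower number from compound 1 to compound 2 (0.93 log units; beyond the scatter), connects the other two and is the largest of the three.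

Compound 4 `COC(=O)c1cc(-c2cccc(OC)c2)c2oc(C(O)(c3ccc(C#N)cc3)c3cncn3C)cc2c1` is not yet measured. Relative to compound 3 it carries methoxycarbonyl in place of nitro on an aromatic carbon. Within the data shown here, the measured steps that bear on this change are the two that alter the group on the same aromatic carbon, a 3.7-fold lower number from compound 1 to compound 3 (0.56 log units; beyond the scatter) and a 2.3-fold higher number from compound 2 to compound 3 (0.36 log units; beyond the scatter); both were modest, and neither involves the group that enters here, so there is no direct precedent for the ester. For compound 4 the step of a 1.3-fold lower number from compound 3 to compound 4 (0.11 log units; within the scatter) is expected to stay within the usual scatter, with no clear direction. The number for compound 4 in this assay is therefore estimated at 30 nM, within a range from 12 nM to 80 nM.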

Compound 4, half-maximal inhibitory concentration: 36.3 nM
Compound 4: middle estimate off by 1.2-fold (0.08 log units), on the low side; the measured number falls inside the stated range.
By their numbers in this assay, from the lowest: compound 2; then compounds 4 and 3 (each within the scatter of the next); then compound 1.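

In this assay, methoxycarbonyl on this aromatic carbon reads the same as nitro, a 1.1-fold lower number from compound 3 to compound 4 (0.03 log units; within the scatter), so the series now has a second group that lands at this level, and one that is not a nitrogen-bearing group. The two groups carry the same counts of hydrogen-bond donors and acceptors and no net charge, and the one extra heavy atom of methoxycarbonyl leaves no readable trace on the number. Compound 4 also sits where compound 3 sat relative to the other two, with a 2.2-fold higher number from compound 2 to compound 4 (0.33 log units; beyond the scatter) and a 3.9-fold lower number from compound 1 to compound 4 (0.59 log units; beyond the scatter), both beyond the scatter, so the hydroxymethyl of compound 2 keeps the lowest number of the four and the (dimethylamino)methyl of compound 1 the highest.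

From the compounds shown here alone, whether this level holds for a carboxylic acid, a primary amide or an ester with a longer chain on the same carbon stays open, as does whether a primary amine or a longer hydroxyalkyl chain would follow compound 1 or compound 2. Nothing at hand accounts for nitro and methoxycarbonyl reading alike or for the gaps to the other two groups.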